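The compounds below may be only part of what the source reports. "The series", "measured", "known", "first", "only" and "open" are said of these compounds alone.

In a toxicity assay on CHO cells (Cricetulus griseus) for cytotoxicity, read by WST assay, with a stated time of 24 h (on this read-out higher numbers stand for weaker inhibition and lower numbers for stronger inhibition), compound 1 `CC(C)=CCCC(C)=CCNCCCN` gives > 150000 nM, which is a limit and not a number. Compound 2 `CC(C)=CCCC(C)=CCNCCCN(C)CCCN` gives > 150000 nM, again a limit. Compound 3 `CC(C)=CCC/C(C)=C\CCC(C)=CCNCCCN` differs from compound 1 by 3-methylbut-2-en-1-yl in place of hydrogen on a saturated chain carbon bound to a double-bonded chain carbon. Going by the values given here, the only measured step, a step that the two limits leave unreadable from compound 1 to compound 2, is a different change and offers no readable size, so the expectation rests on the structural change alone. A moderate move toward stronger inhibition is expected, as an at least 2.5-fold lower number from compound 1 to compound 3 (0.39 log units; beyond the scatter), although this assay may again report only a limit. For compound 3 the estimated value is 60000 nM, with an expected range of 15000 nM to 150000 nM.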

Compound 3, half-maximal inhibitory concentration: 32100 nM
Estimate against measurement, compound 3: 1.9-fold (0.27 log units) above; the range from low to high includes it.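

In this assay, going by these compounds alone, 3-methylbut-2-en-1-yl in place of hydrogen on a saturated chain carbon bound to a double-bonded chain carbon gives the first readable step, an at least 4.6-fold lower number from compound 1 to compound 3 (0.66 log units; beyond the scatter). That size is only a minimum, and compound 3 is the only one of the three compounds to give a number rather than a limit: the limit of > 150000 nM in this assay, at which 2 of the 3 values shown sit.

The compounds shown leave open whether the double bond of the added group matters, which a saturated 3-methylbutyl group in the same place would test. They also leave open whether a longer chain would lower the number further.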